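From Methoxy to Ethylamino in a Solubility Series

The compounds below may be only part of what the source reports. "The series", "measured", "known", "first", "only" and "open" are said of these compounds alone.

In a physicochemical assay for solubility, read by chemiluminescence, measured as kinetic solubility (on this read-out lower numbers stand for lower solubility and higher numbers for higher solubility), compound 1 (`Cn1ncc2c(NS(=O)(=O)c3cccc(Cl)c3Cl)ncnc21`) gives 476000 nM. Compound 2 (`COc1nn(C)c2ncnc(NS(=O)(=O)c3cccc(Cl)c3Cl)c12`) reads >= 581000 nM, which is a limit of the assay and not a number. Compound 3 (`COc1nc(NS(=O)(=O)c2cccc(Cl)c2Cl)c2c(OC)nn(C)c2n1`) gives 148000 nM, the lower of the two actual numbers in the series.

Compound 4 (`CCNc1nc(NS(=O)(=O)c2cccc(Cl)c2Cl)c2c(OC)nn(C)c2n1`) has ethylamino in place of methoxy on an aromatic carbon, between two ring nitrogen atoms: ethylamino in place of methoxy on an aromatic carbon. Going by the values given here, no measured step makes this exact swap. The nearest evidence comes from two steps that put methoxy in place of hydrogen on an aromatic carbon: an at least 1.2-fold higher number from compound 1 to compound 2 (0.08 log units; that floor lies within the scatter), and an at least 3.9-fold lower number from compound 2 to compound 3 (0.59 log units; beyond the scatter). Only the second acts on the carbon that changes here, and it offers a single, indirect guide. A small downward drift that stays within the scatter is therefore expected in this assay. The estimated step is a 1.5-fold lower number from compound 3 to compound 4 (0.17 log units; within the scatter). For compound 4 the expected value is 100000 nM, with an estimated range of 30000 nM to 300000 nM.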

Compound 4, solubility: 219000 nM
Estimate against measurement, compound 4: 2.2-fold (0.34 log units) below, and the stated range covers the measured number.
By their numbers in this assay, from the lowest: compounds 3 and 4 (each within the scatter of the next); then compound 1. At a limit, above all of these: compound 2.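

In this assay the swap to ethylamino in place of methoxy on the carbon between two ring nitrogen atoms gives a 1.5-fold higher number from compound 3 to compound 4 (0.17 log units; within the scatter) and so leaves the reading unchanged within the scatter. Measured against hydrogen on this same carbon, ethylamino gives an at least 2.6-fold lower number from compound 2 to compound 4 (0.42 log units; beyond the scatter) and methoxy gives an at least 3.9-fold lower number from compound 2 to compound 3 (0.59 log units; beyond the scatter) so on this carbon both groups read lower than hydrogen. Compound 2 stands at a limit of the assay and not a number: the limit of >= 581000 nM in this assay, at which 1 of the 4 values shown sits.

The compounds shown leave open whether a different group on this carbon, such as a carboxylic acid, a cyclic amine or a longer chain, would read like compound 3 and compound 4. Going by these compounds, the true size of the drop from hydrogen also stays open, as the starting reading is only a limit.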